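Removing a Trifluoromethyl Group: Expected Effect on Solubility

This account rests on a few compounds, and the source may have more. Where it says the series, first, only, none or still open, it means among the compounds named here.

This account follows a single change made to compound 1, `CNC(=O)c1sc(N2CC3CC2(CNC(=O)c2c[nH]c4ncc(C(F)(F)F)cc24)C3)nc1C(F)(F)F`, and asks what it may do to solubility. In a physicochemical assay for solubility (a lower number here means a less soluble compound, a higher number a more soluble compound), compound 1 gives < 1600 nM, which is a limit of the assay rather than a number. Among the measured compounds shown here, the only other measured compound, compound 2, `C[C@@H]1CN(c2cnc(Nc3cc(F)c(OCC4CC4)c(F)c3)nc2NC2CCOCC2)CCN1`, is built on a different core; in this assay compound 2 gives 400000 nM. For the measured compounds named here, no step between two measured compounds is available, since the two differ in many places at once, so what is known of compound 1 is the limit alone, (the limit of < 1600 nM in this assay, at which 1 of the 2 values shown sits).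

The new compound, compound 3, `CNC(=O)c1sc(N2CC3CC2(CNC(=O)c2c[nH]c4ncccc24)C3)nc1C(F)(F)F`, differs from compound 1 in one place: hydrogen in place of trifluoromethyl on an aromatic carbon. Whether this change moves solubility is not shown by any measured pair. The step of an at least 1.8-fold higher number from compound 1 to compound 3 (0.27 log units; that floor lies within the scatter) is the author's expectation, a modest rise beyond the usual scatter, held with wide uncertainty. Compound 3 is therefore estimated at 3000 nM, within a range from 800 nM to 15000 nM, and it may well return only a limit again.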

Compound 3, solubility: < 1600 nM
Compound 3 ended at the assay's limit; the forecaster's own chance of this, stated with the estimate: 40%; at least 1.8-fold (0.27 log units) between middle value and limit.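

In this assay compound 3 gives < 1600 nM, a limit of the assay and not a number. Among the compounds shown here, compound 1 also stands at a limit, so no step from compound 1 to compound 3 can be read. The compounds shown leave open whether hydrogen in place of trifluoromethyl on an aromatic carbon moves solubility at all, and in which direction.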